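A Benzyl Cap Tested Against Three Assay Limits

The source may hold more compounds than are shown below. What is called first, only, known or untested is meant among the compounds shown, and "the series" means these compounds.

Compound 1 `C[C@H](Oc1cccc(Cl)c1Cl)C(=O)Nc1ccc2oc(-c3ccc(OC(F)(F)F)cc3)nc2c1` was examined in an assay on isolated protein for inhibition of GMP reductase 2 (Homo sapiens), read by spectrophotometry; a lower number here means a stronger inhibitor, a higher number a weaker inhibitor. In this assay compound 1 gives only a limit, > 5000 nM, so no number is known for it. The two other compounds measured fare the same way. Compound 2 `C[C@H](Oc1cccc(F)c1F)C(=O)Nc1ccc2oc(-c3ccncc3)nc2c1` gives a limit of > 5000 nM in this assay. Compound 3 `COc1ccc(-c2cn3cc(NC(=O)[C@H](C)Oc4cccc(Cl)c4Cl)ccc3n2)cc1` likewise gives a limit, > 5000 nM. Going by the values given here, compound 1 therefore cannot be placed on any scale: every value shown sits at the limit of > 5000 nM in this assay, at which 3 of the 3 values shown sit, and no compound in this set is separated from another.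

Compound 4 `COc1ccc(Cc2nc3cc(NC(=O)[C@H](C)Oc4cccc(Cl)c4Cl)ccc3o2)cc1` differs from compound 1 in one place: 4-methoxybenzyl in place of 4-(trifluoromethoxy)phenyl on an aromatic carbon. The exchange sits on an aromatic carbon of a five-membered aromatic ring with 1 nitrogen and 1 oxygen, part of a fused or bridged system of two rings, next to the ring nitrogen and next to the ring oxygen, while the shared core is kept. Among the compounds with values here, no measured pair here shows any change lifting a value off the limit.

With compound 1 itself at a limit, the step that the limit leaves unreadable from compound 1 to compound 4 that this estimate means is expected to be none beyond the scatter. Compound 4 is expected to give about 10000 nM, within 3000 nM to 50000 nM, most likely reported again as a limit.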

Compound 4, inhibition constant: > 5000 nM
Compound 4: a limit, no number; the forecaster's own chance of this, stated with the estimate: 85%; the middle value is on the limit's open side.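

In this assay compound 4 gives > 5000 nM, which is a limit and not a number. Compound 1 also stands at a limit, so the size of the change between compound 1 and compound 4 cannot be read. The compounds shown leave open which change, if any, would give a measurable value, as all share one limit: the limit of > 5000 nM in this assay, at which 4 of the 4 values shown sit.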